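The source may report more compounds than this note shows. Statements on the series, on what has been measured and on what is new or still open speak of the compounds shown alone.

In an ADME assay on microsomes from liver (Rattus norvegicus) for metabolic stability, read by LC-MS, using NADPH, with a stated time of 10 min, tested at 0.1 uM (a lower number here means slower removal, a higher number faster removal of the compound), compound 3 (`O=C(NCCCCc1ccccc1)c1cccc(C2SCC(=O)N2c2cccc(-c3c[nH]nn3)c2)c1`) gives 742 mL.min-1.g-1 and lies within the scatter of compound 1 (`COc1ccc(F)cc1N1C(=O)CSC1c1cccc(C(=O)NCCCCn2cccn2)c1`) with 1470 mL.min-1.g-1 as its value. Compound 2 (`C#Cc1cc(C(=O)NCCCCc2ccccc2)cc(C2SCC(=O)N2c2ccccc2OC)c1`) gives 2200 mL.min-1.g-1 and so stands higher than compound 3 by more than the scatter. Compound 4 (`CC(F)(F)c1cccc(N2C(=O)CSC2c2cccc(C(=O)NCCCCc3ccccc3)c2)c1`) has 1,1-difluoroethyl in place of 1H-1,2,3-triazol-4-yl on an aromatic carbon of compound 3 (1,1-difluoroethyl in place of 1H-1,2,3-triazol-4-yl on an aromatic carbon). Going by the values given here, no measured pair differs in one place only, so any guide is indirect. Compound 3 shares its amide chain with compound 2, which has no triazole and gives 2200 mL.min-1.g-1 as its value, though other parts differ too. An estimated rise beyond the scatter is expected (a 2.4-fold higher number from compound 3 to compound 4 (0.38 log units; beyond the scatter)). The estimate for compound 4 is 1800 mL.min-1.g-1 with 900 mL.min-1.g-1 to 3500 mL.min-1.g-1 as its expected range.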

Compound 4, intrinsic clearance in microsomes: 2320 mL.min-1.g-1
The estimate for compound 4 lay 1.3-fold (0.11 log units) below the measured number; the measured number falls inside the stated range.
By their numbers in this assay, from the lowest: compounds 3, 1, 2 and 4 (each within the scatter of the next, the first and the last beyond it).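

Going by these compounds alone, compounds 3 and 4 differ in one place only, giving the first direct reading for this aromatic carbon, meta to a large group: 1,1-difluoroethyl in place of 1H-1,2,3-triazol-4-yl gives a 3.1-fold higher number from compound 3 to compound 4 (0.50 log units; beyond the scatter) in this assay. Within the data shown here, the swap therefore goes with faster removal, a link the earlier compounds could not isolate. Nothing measured here explains the rise. This single pair cannot separate the loss of the triazole from the gain of 1,1-difluoroethyl. A plain hydrogen, an amine or a carboxylic acid on that carbon would help to divide the step between them.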